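A few compounds are considered here, and "the series" means these few. Any claim that something is new, unique, unknown or untested is made for them only; others in the source may bear on it.

Measured so far:
Compound 1, `Nc1scc(CN2CCN(c3cccc4ccccc34)CC2)c1C(=O)c1ccc(Cl)cc1`: 8.7%
Compound 2, `Nc1scc(CN2CCN(c3ccccc3F)CC2)c1C(=O)c1ccc(Cl)cc1`: 2.1%

In a functional assay on CHO cells with adenosine receptor A1 (Homo sapiens) as the target, read by cAMP accumulation and immunoassay, with a stated time of 6 min, tested at 0.01 uM (a higher number here means a weaker effect of the compound at the concentration tested, a lower number a stronger effect), compound 2 gives 2.1%, and compound 1 gives 8.7%. Within the data shown here, the single measured step, a number 6.6 percentage points lower from compound 1 to compound 2 (within the scatter), lies within the scatter, so the two compounds cannot be told apart on these numbers; both read-outs are small. Compound 3, `Nc1scc(CN2CCN(c3cc(F)cc(F)c3)CC2)c1C(=O)c1ccc(Cl)cc1`, is the next compound, and it differs from compound 2 in one place: 3,5-difluorophenyl in place of 2-fluorophenyl on an amine nitrogen in a ring. Among the measured compounds shown here, the only step that bears on this change is the one from compound 1 to compound 2, which also exchanged the aromatic group on the same ring nitrogen and produced nothing beyond the scatter. For the measured compounds named here, no other step is available. The move from compound 2 to compound 3 is therefore expected to give a step of a number 2.9 percentage points higher from compound 2 to compound 3 (within the scatter), which is within the scatter. Compound 3 is estimated to give 5%, with a range from -4% to 15%.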

Compound 3, a percentage reported as activity, at one concentration (the size of the read-out at that concentration, not a potency): -13%
Estimate against measurement, compound 3: 18 percentage points above, outside the stated range (below it).
By their numbers in this assay, from the lowest: compound 3; then compounds 2 and 1 (each within the scatter of the next).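

At this position, the amine nitrogen in the six-membered ring, the choice of aromatic group can move the read-out in this assay: the change to 3,5-difluorophenyl gives a number 15.1 percentage points lower from compound 2 to compound 3 (beyond the scatter) and a number 21.7 percentage points lower from compound 1 to compound 3 (beyond the scatter), whereas the earlier exchange of naphthalen-1-yl for 2-fluorophenyl stayed within the scatter. Compound 3 therefore has the lowest number of the three, which here means the strongest effect at the concentration tested, but the change from compound 2 both adds a fluorine and alters the fluorine pattern, and these two differences cannot be separated. Nothing shown explains why this change lowers the number.

Going by these compounds, it remains open whether 3-fluorophenyl, with a single fluorine, would behave like 3,5-difluorophenyl. On these data alone, it is also open whether 3,5-dichlorophenyl or 3,5-dimethoxyphenyl, with chlorine atoms or methoxy groups in place of the fluorines, would give a similar read-out.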